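A few compounds are considered here, and "the series" means these few. Any claim that something is new, unique, unknown or untested is made for them only; others in the source may bear on it.

Compound 1, `CCOC(=O)Cn1cc(-c2ccc(OC)c(OC)c2OC)nn1`: in a functional assay on B16 cells (Mus musculus) for cytotoxicity, read by MTT assay, with a stated time of 48 h (on this read-out higher numbers stand for weaker inhibition and lower numbers for stronger inhibition), compound 1 gives > 100000 nM, which is a limit of the assay and not a number.
Compound 2, `COc1ccc(C(O)c2cn(CCCO)nn2)c(OC)c1OC`: in this assay compound 2 gives > 100000 nM, again a limit rather than a number.

The two measured compounds share the same core, and neither yields a real number in this assay: both sit at the limit of > 100000 nM in this assay, at which 2 of the 2 values shown sit. Among the compounds with values here, compound 1 therefore stands at the ceiling of what this assay can report, and the one other value shown sits at that same ceiling, so no order between compound 1 and compound 2 can be read from these values. Within the data shown here, no step between two measured compounds can be computed here, as both values are limits.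

Compound 3, `COc1ccc(-c2cn(Cc3ccccc3)nn2)c(OC)c1OC`, has not yet been measured. It differs from compound 1 in one place: phenyl in place of ethoxycarbonyl on a saturated chain carbon bound to an aromatic nitrogen. With only limits in hand, nothing measured points toward stronger or weaker inhibition for compound 3. The expected step is a number no higher from compound 1 to compound 3 (the limit leaves the size open), nothing beyond the scatter. Compound 3 is most likely to return only a limit again, and the estimate for compound 3 is about 100000 nM, within 30000 nM to 300000 nM.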

Compound 3, half-maximal inhibitory concentration: 27500 nM
Compound 3: middle estimate off by 3.6-fold (0.56 log units), on the high side, and the stated range ends above it.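

Compound 3 is the only compound shown that gives a real number in this assay, so the group on the saturated chain carbon bound to an aromatic nitrogen can decide whether this core registers at all in the read-out. Putting phenyl in place of ethoxycarbonyl, which turns (ethoxycarbonyl)methyl into benzyl, gives an at least 3.6-fold lower number from compound 1 to compound 3 (0.56 log units; beyond the scatter), a shift toward stronger inhibition. The true size of this step stays unknown, because compound 1 gives a limit and not a number: the limit of > 100000 nM in this assay, at which 2 of the 3 values shown sit.

The compounds shown cannot separate the effect of gaining an aromatic ring from that of losing the ethoxycarbonyl group, as both happen in the same change. A cyclohexyl group, which has a ring that is not aromatic, a plain butyl chain, which has no ring, or a benzyl carrying an amine or a carboxylic acid on its phenyl ring would each help to show which part of the change matters and how much room this place offers.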